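Predicting a hydroxymethylphenyl analogue of compound 1

The source may report more compounds than this note shows. Statements on the series, on what has been measured and on what is new or still open speak of the compounds shown alone.

Compound 1 `CCCC[S+]([O-])c1sc2nc(-c3nccs3)cc(-c3ccc(C(=O)OC)cc3)c2c1N` gives 15.1 nM in an assay for inhibition of 15-hydroxyprostaglandin dehydrogenase [NAD(+)] (Homo sapiens), read by fluorescence, with a stated time of 15 min, in the presence of a further agent that is not named here; on this read-out lower numbers stand for stronger inhibition and higher numbers for weaker inhibition.
Compound 2 `Nc1c(C(=O)O)sc2nc(-c3cccs3)cc(-c3ccccc3)c12` reaches only the limit > 7500 nM in this assay.
Compound 3 `CCCCSc1sc2nc(-c3cccs3)cc(-c3ccccc3)c2c1N` reaches only the limit > 80 nM in this assay.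

Among the measured compounds shown here, compound 1 holds the only definite number among the three; the values for compound 2 and compound 3 are assay limits rather than measurements (the limit of > 7500 nM in this assay, at which 1 of the 3 values shown sits, (the limit of > 80 nM in this assay, at which 1 of the 3 values shown sits)). For the measured compounds named here, the single measured step, a step that the two limits leave unreadable from compound 2 to compound 3, cannot be read in size, and it concerns a different part of the shared core than the change now followed.

Compound 4 `CCCC[S+]([O-])c1sc2nc(-c3nccs3)cc(-c3cccc(CO)c3)c2c1N` differs from compound 1 as follows: 3-(hydroxymethyl)phenyl in place of 4-(methoxycarbonyl)phenyl on an aromatic carbon. Going by the values given here, no measured step touches this position, so the data give no anchor for the direction of the change. With nothing to point either way, compound 4 is expected to sit close to compound 1, within or only a little beyond the usual scatter, and the step of a 1.7-fold higher number from compound 1 to compound 4 (0.22 log units; within the scatter) is therefore estimated as small. Compound 4 is estimated at 25 nM in this assay, with a range from 8 nM to 100 nM.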

Compound 4, half-maximal inhibitory concentration: 4.3 nM
Compound 4: middle estimate off by 5.8-fold (0.76 log units), on the high side; measured number below the stated range.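

At this position on the shared core, opposite the ring nitrogen, the data now hold their first readable step: in this assay, 3-(hydroxymethyl)phenyl in place of 4-(methoxycarbonyl)phenyl gives a 3.5-fold lower number from compound 1 to compound 4 (0.55 log units; beyond the scatter) and lies beyond the usual scatter. The methoxycarbonyl group is therefore not needed for a low number on this core, and the smaller group with one hydrogen-bond donor gives the lower number of the pair. Nothing shown explains the shift, since the only other information is a pair of assay limits on compounds that differ elsewhere.

The step changes both the group and its place on the phenyl ring, and the compounds shown do not separate these two changes. On these data alone, it also remains open how 4-(hydroxymethyl)phenyl, 3-(methoxycarbonyl)phenyl or a 3-(aminomethyl)phenyl group with its amine would read here.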